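From compound 3 to compound 4: a 5-methylthiophen-2-yl swap

The compounds below may be only part of what the source reports. "The series", "measured", "known", "first", "only" and "open" are said of these compounds alone.

In a functional assay on MCF7 cells (Homo sapiens) for cytotoxicity, read by MTT assay, with a stated time of 48 h (a lower number here means a stronger inhibitor, a higher number a weaker inhibitor), compound 1 `O=C1/C(=C\c2ccc(Cl)cc2)S/C(=N/c2ccccc2)N1Cc1ccncc1` gives 54900 nM with 4-chlorophenyl on the double-bonded chain carbon, compound 2 `O=C1/C(=C\c2ccc(O)c(O)c2)S/C(=N/c2ccccc2)N1Cc1ccncc1` gives 12400 nM with 3,4-dihydroxyphenyl there, and compound 3 `COc1cc(/C=C2/S/C(=N/c3ccccc3)N(Cc3ccncc3)C2=O)ccc1O` gives 28000 nM with 4-hydroxy-3-methoxyphenyl there. Compound 3 thus holds the second highest of the three numbers, within the scatter of compound 1 and beyond it from compound 2.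

Compound 4 `Cc1ccc(/C=C2/S/C(=N/c3ccccc3)N(Cc3ccncc3)C2=O)s1` has 5-methylthiophen-2-yl in place of 4-hydroxy-3-methoxyphenyl on a double-bonded chain carbon bound to a double-bonded ring carbon is the counted change.

Among the measured compounds shown here, three measured steps bear on this. Changes at the same place gave a 4.4-fold lower number from compound 1 to compound 2 (0.65 log units; beyond the scatter) for 3,4-dihydroxyphenyl and a 2.0-fold lower number from compound 1 to compound 3 (0.29 log units; within the scatter) for 4-hydroxy-3-methoxyphenyl, while methyl on an oxygen gave a 2.3-fold higher number from compound 2 to compound 3 (0.35 log units; beyond the scatter) in this series. All are small, and no thiophene has been measured here. The nearest guide is compound 1 (54900 nM), whose group also has no hydroxy. No step beyond the scatter is therefore firmly expected in this assay, with a lean towards a higher number. The estimate means an expected 1.6-fold higher number from compound 3 to compound 4 (0.21 log units; within the scatter) at most. Compound 4 is estimated at 45000 nM with an expected range of 16000 nM to 120000 nM in repeat measurements.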

Compound 4, half-maximal inhibitory concentration: 28700 nM
For compound 4 the middle estimate is 1.6-fold (0.20 log units) above the measured one, and the stated range covers the measured number.
By their numbers in this assay, from the lowest: compound 2; then compounds 3, 4 and 1 (each within the scatter of the next).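

With 5-methylthiophen-2-yl in place of 4-hydroxy-3-methoxyphenyl, this assay gives a 1.0-fold higher number from compound 3 to compound 4 (0.01 log units; within the scatter) and so does not separate the two groups, which shows that neither a six-membered aromatic ring of carbon only nor a hydrogen-bond donor on this group is required at this place to reach the level of compound 3. Among the compounds shown here, the comparison with the 4-chlorophenyl group gives a 1.9-fold lower number from compound 1 to compound 4 (0.28 log units; within the scatter) and also stays within the scatter, while the comparison with the 3,4-dihydroxyphenyl group gives a 2.3-fold higher number from compound 2 to compound 4 (0.36 log units; beyond the scatter) and leaves compound 2 as the only compound of the four set apart, with the lowest number. The data offer no measurement that accounts for the standing of any of these groups.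

As far as these compounds go, whether an amine or a carboxylic acid on the aromatic ring at this place would fall with compound 2 or with the other three remains open. The part played by the methyl of 5-methylthiophen-2-yl is also unresolved, since no thiophen-2-yl group without it appears among the compounds shown.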